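This account rests on a few compounds, and the source may have more. Where it says the series, first, only, none or still open, it means among the compounds named here.

Of the compounds shown here, two of a shared epoxide-ester core have been tested in a functional assay for inhibition, with Rattus norvegicus as the target; a higher number here means that more compound is needed for the effect, a lower number that less compound is needed. Compound 1, `CCCCC/C=C/CCCCCCCCCC1(C(=O)OC)CO1`, carries a chain with one double bond and a methyl ester; in this assay compound 1 gives 5 uM. Compound 2, `CCCCCCCCCCCCCCC1(C(=O)OCC(O)CO)CO1`, carries a fully saturated chain and an ester of glycerol; in this assay compound 2 gives 10 uM. Compound 2 stands at the higher of the two numbers, but the gap to compound 1 lies within the usual scatter of repeated measurements, so the two cannot be told apart on these data.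

The next compound, compound 3, `CCCCCCCCCCCCCCC1(C(=O)OCCCC)CO1`, keeps the saturated chain and the core of compound 2 and changes only the ester group: propyl in place of 1,2-dihydroxyethyl on a saturated chain carbon bound to an oxygen next to a carbonyl group. Going by the values given here, no pair of measured compounds differing in one place is available, so the size of this step cannot be read from the data. The expectation is therefore that the step of a 1.4-fold lower number from compound 2 to compound 3 (0.15 log units; within the scatter) stays within the scatter, with no clear change in either direction. On that basis compound 3 is estimated at 7 uM in this assay, with a range from 2 uM to 25 uM.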

Compound 3, minimum effective concentration: 10 uM
Estimate against measurement, compound 3: 1.4-fold (0.15 log units) below; low and high end bracket the measured number.
By their numbers in this assay, from the lowest: compounds 1, 2 and 3 (each within the scatter of the next).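

In this assay, putting propyl in place of 1,2-dihydroxyethyl on a saturated chain carbon bound to an oxygen next to a carbonyl group gives no change at the digits printed from compound 2 to compound 3 (within the scatter). Going by these compounds alone, this is the first comparison here of two compounds that differ in one place, and it shows that this position tolerates a clear change in the ester group: the group that leaves has 2 hydrogen-bond donors and 2 hydrogen-bond acceptors, the group that enters has 0 of each, and the read-out does not separate the two compounds. Nothing measured here explains this outcome.

On these data alone, the result covers a single swap on the saturated chain, so it remains open whether the same swap would give the same outcome on the chain with one double bond that compound 1 carries. As far as these compounds go, it also remains open how far this tolerance extends, for instance to a carboxylic acid in place of the ester or to an amine at the end of the butyl group.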